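Replacing the imidazole in a desaturase inhibitor series

The source may hold more compounds than are shown below. What is called first, only, known or untested is meant among the compounds shown, and "the series" means these compounds.

Of the compounds shown here, three sharing one core have been measured. Compound 1 `FC(F)(F)c1ccccc1OC1CCN(c2ccc(-n3ccnc3)nn2)CC1` gives 4 nM in an assay on microsomes from liver for inhibition of acyl-CoA desaturase 1 (Rattus norvegicus); on this read-out lower numbers stand for stronger inhibition and higher numbers for weaker inhibition. Compound 2 `CCc1ccccc1OC1CCN(c2ccc(-n3ccnc3)nn2)CC1` gives 4 nM in this assay, and no change at the digits printed from compound 1 to compound 2 (within the scatter). Compound 3 `COc1ccccc1OC1CCN(c2ccc(-n3ccnc3)nn2)CC1` gives 543 nM, and a 140-fold higher number from compound 1 to compound 3 (2.13 log units; beyond the scatter), as does a 140-fold higher number from compound 2 to compound 3 (2.13 log units; beyond the scatter). Compound 1 therefore stands level with compound 2, and together they hold the lowest numbers of the three, while compound 3 lies far from both.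

Compound 4 `Oc1nnc(-c2ccc(N3CCC(Oc4ccccc4C(F)(F)F)CC3)nn2)s1` has not been measured. It differs from compound 1 in this way: 5-hydroxy-1,3,4-thiadiazol-2-yl in place of 1H-imidazol-1-yl on an aromatic carbon. The trifluoromethyl on the other ring, which separates compound 1 from compound 3, is kept unchanged.

None of the three measured steps touches the ring that changes here; every one of them concerns the substituent that the new compound retains. Among the compounds with values here, the data give no step of the same kind to lean on, so the size and direction of the step in this assay cannot be read from them. Compound 4 is expected to land in the vicinity of compound 1, with a wide margin on either side, and the estimated step is a 5.0-fold higher number from compound 1 to compound 4 (0.70 log units; beyond the scatter). The estimate for compound 4 in this assay is 20 nM, ranging from 2 nM to 300 nM.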

Compound 4, half-maximal inhibitory concentration: 6.1 nM
Estimate against measurement, compound 4: 3.3-fold (0.52 log units) above, and the stated range covers the measured number.
By their numbers in this assay, from the lowest: compounds 1, 2 and 4 (each within the scatter of the next); then compound 3.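

At this position, on an aromatic carbon of the six-membered aromatic ring with 2 nitrogen, the change from 1H-imidazol-1-yl to 5-hydroxy-1,3,4-thiadiazol-2-yl gives in this assay a 1.5-fold higher number from compound 1 to compound 4 (0.18 log units; within the scatter). Within the data shown here, all the earlier compounds carried 1H-imidazol-1-yl and differed only on the other ring, so only this step shows that a low number in this read-out does not depend on that group, since a five-membered aromatic ring with 3 hetero atoms, including sulfur, and with 1 hydrogen-bond donor serves as well in this one pair. Nothing shown explains why the two groups fall within the scatter of each other.

The compounds shown leave open whether the hydroxy on the new ring matters to this number, which a methyl, an amine or a carboxylic acid in its place would test. They also leave open whether the large step seen with methoxy in place of trifluoromethyl, a 140-fold higher number from compound 1 to compound 3 (2.13 log units; beyond the scatter), recurs when 5-hydroxy-1,3,4-thiadiazol-2-yl stands in place of 1H-imidazol-1-yl.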